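The source may hold more compounds than are shown below. What is called first, only, known or untested is meant among the compounds shown, and "the series" means these compounds.

Three members of one series, all built on the same core, have been measured in a functional assay (MiaPaCa cells, Homo sapiens) for inhibition, read by sulforhodamine B assay, with a stated time of 48 h; on this read-out higher numbers stand for weaker inhibition of growth and lower numbers for stronger inhibition of growth. Compound 1 `CC(C)(C)OC(=O)N1CCN(C(=O)CCN2C(=O)CSc3ccccc32)CC1` gives 51500 nM in this assay. Compound 2 `COc1ccccc1N1CCN(C(=O)CCN2C(=O)CSc3ccccc32)CC1` carries a 2-methoxyphenyl where compound 1 carries a tert-butoxycarbonyl. In this assay compound 2 gives 34900 nM; the step of a 1.5-fold lower number from compound 1 to compound 2 (0.17 log units; within the scatter) stays within the scatter. Compound 3 `O=C(CCN1C(=O)CSc2ccccc21)NCCCN1CCN(c2ccc([N+](=O)[O-])cc2)CC1` reaches only a limit of the assay, > 100000 nM, so no number is known for it. That is the limit of > 100000 nM in this assay, at which 1 of the 3 values shown sits, and compound 3 stands there alone among the three.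

Compound 4 `O=C(CCN1C(=O)CSc2ccccc21)NCCCN1CCN(c2ccccc2F)CC1` differs from compound 3 in one place: 2-fluorophenyl in place of 4-nitrophenyl on an amine nitrogen in a ring. Among the compounds with values here, the only measured step that bears on a swap of the group on that ring nitrogen is a 1.5-fold lower number from compound 1 to compound 2 (0.17 log units; within the scatter), which was within the scatter, though it exchanged other groups than the present one. Within the data shown here, nothing among the measured compounds points to a large shift in either direction. Compound 4 is therefore expected to give about 70000 nM, within a range from 25000 nM to 200000 nM. The expected step of an at least 1.4-fold lower number from compound 3 to compound 4 (0.15 log units; that floor lies within the scatter) starts from a limit and is itself only an estimate, which may again end in a limit.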

Compound 4, concentration for 50% growth inhibition: > 100000 nM
Compound 4: a limit, no number; the forecaster's own chance of this, stated with the estimate: 45%; middle value at least 1.4-fold (0.15 log units) from the limit.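

Compound 3 and compound 4 both give no number, so no step can be read between them; they share one limit: the limit of > 100000 nM in this assay, at which 2 of the 4 values shown sit.

The compounds shown leave open whether 2-fluorophenyl and 4-nitrophenyl on that ring nitrogen differ at all in this assay.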